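A few compounds are considered here, and "the series" means these few. Any claim that something is new, unique, unknown or untested is made for them only; others in the source may bear on it.

Measured so far:
- compound 1 `Cc1cccc(NNC(=O)c2ccc(NS(=O)(=O)c3cnc(O)nc3O)cc2)c1`: > 20000 nM
- compound 2 `Cc1cccc(NNC(=O)c2cccc(NS(=O)(=O)c3cnc(O)nc3O)c2)c1`: > 20000 nM
- compound 3 `O=C(NNc1cccc(Cl)c1)c1ccccc1NS(=O)(=O)c1cnc(O)nc1O`: 5290 nM

In a functional assay on A549 cells (Homo sapiens) for antiproliferative activity, read by MTT assay, with a stated time of 24 h (on this read-out lower numbers stand for stronger inhibition and higher numbers for weaker inhibition), compound 1 gives > 20000 nM, which is a limit and not a number. Compound 2 gives > 20000 nM, which is also a limit. Going by the values given here, compound 3 gives 5290 nM, the only true number so far. Compound 1 therefore stands on (the limit of > 20000 nM in this assay, at which 2 of the 3 values shown sit).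

Compound 4 `Cc1ccc(C(=O)NNC(=O)c2ccc(NS(=O)(=O)c3cnc(O)nc3O)cc2)cc1` carries (4-methylphenyl)carbonyl in place of 3-methylphenyl on an amine nitrogen. Among the compounds with values here, no measured pair isolates this change, so the expectation rests on the starting point alone. In this assay no clear step in either direction is expected, only a change within the usual scatter, and a second limit reading is quite possible. The estimated a number no higher from compound 1 to compound 4 (the limit leaves the size open) is correspondingly small. For compound 4 the expected value is 20000 nM, with an estimated range of 7000 nM to 50000 nM.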

Compound 4, half-maximal inhibitory concentration: 15900 nM
Beside the measured number, compound 4's estimate is 1.3-fold (0.10 log units) above it; measured number inside the range.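

In this assay, putting (4-methylphenyl)carbonyl in place of 3-methylphenyl on an amine nitrogen gives an at least 1.2-fold lower number from compound 1 to compound 4 (0.09 log units; that floor lies within the scatter). Compound 4 gives 15900 nM, so this position accepts the larger acyl group and still yields a true number, but the step shows no gain beyond the scatter. Compound 1 gives > 20000 nM, which is a limit, so the real size of the step stays unknown: the limit of > 20000 nM in this assay, at which 2 of the 4 values shown sit.

The carbonyl and the move from 3-methylphenyl to the 4-methylphenyl group change together here, so neither can be read alone. Also open, on these data alone, is how this amine nitrogen would respond to a different group, such as a plain acetyl, a longer alkyl chain or a carboxylic acid on the aromatic ring.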